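The source may hold more compounds than are shown below. What is called first, only, known or untested is meant among the compounds shown, and "the series" means these compounds.

Measured so far:
compound 1 `CC(C)[C@H](NC(=O)COc1cccc2ccccc12)C(=O)N[C@@H](CC(=O)O)C(=O)CSc1nc(-c2ccccc2)cs1` — > 200000 nM
compound 2 `CC(C)[C@H](NC(=O)COc1cccc2ccccc12)C(=O)N[C@@H](CC(=O)O)C(=O)CSc1nncn1C` — > 200000 nM
compound 3 `CC(C)[C@H](NC(=O)COc1cccc2ccccc12)C(=O)N[C@@H](CC(=O)O)C(=O)COc1ccnc(C(F)(F)F)n1` — 37000 nM

In a functional assay on Jurkat cells (Homo sapiens) for inhibition (a lower number here means a stronger inhibitor, a higher number a weaker inhibitor), compound 1 gives > 200000 nM, which is a limit of the assay and not a number. Compound 2 gives > 200000 nM, again a limit. Compound 3 gives 37000 nM. Compound 1 therefore stands at the limit of > 200000 nM in this assay, at which 2 of the 3 values shown sit; one of the two other values is a limit as well, so its place among the three is fixed only relative to compound 3.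

The step to compound 4 `CC(C)[C@H](NC(=O)COc1cccc2ccccc12)C(=O)N[C@@H](CC(=O)O)C(=O)COc1ccc2ccccc2n1` is (quinolin-2-yl)oxy in place of (4-phenyl-1,3-thiazol-2-yl)sulfanyl on a saturated chain carbon bound to a carbonyl carbon. Among the measured compounds shown here, three measured steps touch this position. The step that the two limits leave unreadable from compound 1 to compound 2 exchanges one heteroaryl on the sulfur for another. The steps of an at least 5.4-fold lower number from compound 1 to compound 3 (0.73 log units; beyond the scatter) and an at least 5.4-fold lower number from compound 2 to compound 3 (0.73 log units; beyond the scatter) both replace a heteroarylsulfanyl with an aryloxy on the saturated chain carbon bound to a carbonyl carbon, and both run downward beyond the scatter. Compound 4 carries an aryloxy group at the same place, so a downward step an at least 5.0-fold lower number from compound 1 to compound 4 (0.69 log units; beyond the scatter) is expected, of a size comparable to the step from compound 1 to compound 3. Compound 4 is accordingly estimated at 40000 nM in this assay, within 8000 nM to 200000 nM, with a real chance that only a limit is returned.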

Compound 4, half-maximal inhibitory concentration: > 200000 nM
Compound 4 gave a limit, no number; the forecaster's own chance of this, stated with the estimate: 25%; at least 5.0-fold (0.69 log units) between middle value and limit.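

An aryloxy group on the saturated chain carbon bound to a carbonyl carbon does not by itself carry activity: in this assay, quinolin-2-yl in place of 2-(trifluoromethyl)pyrimidin-4-yl on the oxygen gives an at least 5.4-fold higher number from compound 3 to compound 4 (0.73 log units; beyond the scatter). Compound 4 therefore goes against any reading of oxygen-linked groups as better than sulfur-linked ones, and among the compounds shown the measurable activity belongs to the single group in compound 3, not to the oxygen link as such. Among the compounds shown here, the steps from compound 1 and from compound 2 to compound 4 cannot be read, as both ends of each are limits, and compound 3 remains the only compound at this position with a number: the limit of > 200000 nM in this assay, at which 3 of the 4 values shown sit.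

On these data alone, it remains open whether the trifluoromethyl or the ring bearing it separates compound 3 from the others; a nitrile in place of the trifluoromethyl, or an unsubstituted pyrimidin-4-yl on the oxygen, would address this. Also open, as far as these compounds go, is whether (2-(trifluoromethyl)pyrimidin-4-yl)sulfanyl on the same carbon would match compound 3, which would show how much the oxygen link contributes with this group.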